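Third Methoxy Added to Two Growth-Inactive Compounds

The source may hold more compounds than are shown below. What is called first, only, known or untested is meant among the compounds shown, and "the series" means these compounds.

compound 1 `COc1ccc(/C=C/C2CC=CC(=O)N2)c(OC)c1` — > 964 uM
compound 2 `COc1ccc(/C=C/C2CC=CC(=O)N2)cc1OC` — > 964 uM

In a functional assay on U-251 cells (Homo sapiens) for inhibition, read by sulforhodamine B assay, with a stated time of 48 h (on this read-out higher numbers stand for weaker inhibition of growth and lower numbers for stronger inhibition of growth), compound 1 returns only a limit, > 964 uM. In this assay compound 2 likewise returns only a limit, > 964 uM. Compound 2 thus shares (the limit of > 964 uM in this assay, at which 2 of the 2 values shown sit). Compound 3, `COc1cc(OC)c(OC)cc1/C=C/C1CC=CC(=O)N1`, differs from compound 2 by methoxy in place of hydrogen on an aromatic carbon. Among the compounds with values here, with both measured values at the limit, no step between them can be sized. The added methoxy is expected to leave the result where it is, so the expected step that the limit leaves unreadable from compound 2 to compound 3 is none beyond the scatter. Compound 3 is therefore expected to give 1000 uM, within 300 uM to 3000 uM, most likely again only as a limit.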

Compound 3, concentration for growth inhibition (reported as GI): > 864 uM
Compound 3 gave a limit, no number (the forecaster's own chance of this, stated with the estimate: 85%); the middle value lies beyond the limit too.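

In this assay compound 1, compound 2 and compound 3 all return only limits, so the steps from compound 1 and compound 2 to compound 3 cannot be read. The compounds shown leave open whether the added methoxy changes growth inhibition at all.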